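From methyl to (2-nitrophenyl)sulfonyl on compound 2

The source may report more compounds than this note shows. Statements on the series, on what has been measured and on what is new or still open speak of the compounds shown alone.

Measured in a functional assay on SK-OV-3 cells (Homo sapiens) for cytotoxicity, read by MTT assay, with a stated time of 3 days; a higher number here means a weaker inhibitor, a lower number a stronger inhibitor:
- compound 1 `N#Cc1c(Nc2ccccn2)nc(SCc2nc3ccccc3[nH]2)nc1-c1ccccc1`: 5.81 nM
- compound 2 `CN1CCN(c2nc(SCc3nc4ccccc4[nH]3)nc(-c3ccccc3)c2C#N)CC1`: 1600 nM

Of the two measured compounds, compound 2 holds the higher number, 1600 nM. Next in the series is compound 3 `N#Cc1c(-c2ccccc2)nc(SCc2nc3ccccc3[nH]2)nc1N1CCN(S(=O)(=O)c2ccccc2[N+](=O)[O-])CC1`, with (2-nitrophenyl)sulfonyl in place of methyl on an amine nitrogen in a ring. For the measured compounds named here, the only measured step is a 280-fold higher number from compound 1 to compound 2 (2.44 log units; beyond the scatter), which is large and beyond the scatter. That step exchanged (pyridin-2-yl)amino for 4-methylpiperazin-1-yl on an aromatic carbon, so it bears only indirectly on the new change. Going by the values given here, no measured step covers a change on this nitrogen. A moderate step towards a lower number in this assay is expected, with wide uncertainty in both size and direction. The expected step is a 3.2-fold lower number from compound 2 to compound 3 (0.51 log units; beyond the scatter). Compound 3 is estimated at 500 nM, with an expected range of 50 nM to 5000 nM.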

Compound 3, half-maximal inhibitory concentration: 3.2 nM
Beside the measured number, compound 3's estimate is 160-fold (2.19 log units) above it, outside the stated range (below it).
By their numbers in this assay, from the lowest: compounds 3 and 1 (each within the scatter of the next); then compound 2.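

In this assay the amine nitrogen of the six-membered ring proves a highly sensitive position: a 500-fold lower number from compound 2 to compound 3 (2.70 log units; beyond the scatter) accompanies the exchange of methyl for (2-nitrophenyl)sulfonyl. The high number of compound 2 therefore does not follow from the six-membered ring with 2 nitrogen as such, since compound 3 keeps that ring and gives 3.2 nM in the same assay. No measurement shown here accounts for the size of this step.

From the compounds shown here alone, it remains open which part of the entering group carries the step; a phenylsulfonyl, a methylsulfonyl or an acetyl on the same nitrogen would separate the sulfonyl, the aromatic ring and the nitro group. A free ring nitrogen bearing only hydrogen would show how much of the step depends on the loss of methyl.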